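Swapping trifluoromethyl for trifluoromethoxy in compound 3

The source may hold more compounds than are shown below. What is called first, only, known or untested is meant among the compounds shown, and "the series" means these compounds.

Three compounds have numbers in a functional assay on CWR22R cells (Homo sapiens) for antiproliferative activity, read by propidium iodide staining, with a stated time of 96 h; on this read-out higher numbers stand for weaker inhibition and lower numbers for stronger inhibition. Compound 1 `CC(O)(CSc1ccccc1OC(F)(F)F)C(=O)Nc1ccc(S(F)(F)(F)(F)F)cc1` gives 15000 nM, compound 2 `CC(O)(COc1cccc(C(F)(F)F)c1)C(=O)Nc1ccc(S(F)(F)(F)(F)F)cc1` gives 14600 nM, and compound 3 `CC(O)(COc1ccccc1C(F)(F)F)C(=O)Nc1ccc(S(F)(F)(F)(F)F)cc1` gives 1400 nM, the lowest of the three and beyond the scatter from both others.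

The next compound, compound 4 `CC(O)(COc1ccccc1OC(F)(F)F)C(=O)Nc1ccc(S(F)(F)(F)(F)F)cc1`, keeps compound 3 except for one group: trifluoromethoxy in place of trifluoromethyl on an aromatic carbon. Trifluoromethoxy stands in place of trifluoromethyl on an aromatic carbon, ortho to a large group.

For the measured compounds named here, one measured step bears on this change: a 10-fold lower number from compound 2 to compound 3 (1.02 log units; beyond the scatter), a large step in which 2-(trifluoromethyl)phenyl took the place of 3-(trifluoromethyl)phenyl. That step concerns where the group sits, and compound 4 leaves that place unchanged. Going by the values given here, no measured step exchanges the group itself, so the data do not show the size of this swap directly. Among the compounds with values here, compound 1 also bears trifluoromethoxy and gives 15000 nM, yet it differs from compound 3 in more than one place and yields no step.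

With the placement kept, no step beyond the scatter is expected in this assay. The estimated change is a 1.7-fold higher number from compound 3 to compound 4 (0.23 log units; within the scatter), a small rise. For compound 4 the estimated value is 2400 nM, with an expected range from 700 nM to 9000 nM.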

Compound 4, half-maximal inhibitory concentration: 7300 nM
Estimate against measurement, compound 4: 3.0-fold (0.48 log units) below, and the stated range covers the measured number.
By their numbers in this assay, from the lowest: compound 3; then compounds 4, 2 and 1 (each within the scatter of the next, the first and the last beyond it).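

In this assay the exchange of the group itself is not neutral at this aromatic carbon: the measured result is a 5.2-fold higher number from compound 3 to compound 4 (0.72 log units; beyond the scatter) and so lies beyond the scatter. For the compounds shown here, the earlier compounds spoke only to where trifluoromethyl sits, through a 10-fold lower number from compound 2 to compound 3 (1.02 log units; beyond the scatter) as the one step available, whereas this step keeps the place and changes the group. Together the two steps show that the number in this series responds to the identity of the group on this carbon as well as to its place, with trifluoromethyl giving the lower number of the two groups compared here, and nothing at hand gives a reason for the step.

The compounds shown leave open how other groups on this aromatic carbon, such as a chlorine atom, a methyl or a nitrile, would compare with the trifluoromethyl of compound 3. They also leave open whether the step would keep its size if a nitrile replaced the sulfur-bearing group on the anilide ring of the shared core.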